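The source may report more compounds than this note shows. Statements on the series, on what has been measured and on what is new or still open speak of the compounds shown alone.

Of the compounds shown here, three built on a shared core have been tested in an ADME assay on Vero cells (Chlorocebus sabaeus) for cytotoxicity, read by resazurin assay, with a stated time of 3 days; a lower number here means a stronger inhibitor, a higher number a weaker inhibitor. Compound 1 `CN(C)c1cc2[nH]c(C3CCCCC3)nc2cc1NC(=O)c1ccccc1` reaches only the limit of that assay: in this assay compound 1 gives > 100 ug/mL. Compound 2 `CN(C)c1cc2[nH]c(C3CCCCC3)nc2cc1NC(=O)c1cccs1` likewise stands at a limit, and in this assay compound 2 gives > 100 ug/mL. Compound 3 `COCCOC(=O)Nc1cc2nc(C3CCCCC3)[nH]c2cc1N1CCCC1` too is reported as a limit, with > 100 ug/mL in this assay. Within the data shown here, because every value sits at the limit of > 100 ug/mL in this assay, at which 3 of the 3 values shown sit, no compound can be placed above or below another, and the one measured step, a step that the two limits leave unreadable from compound 1 to compound 2, tells nothing about how the group on the carbonyl carbon matters.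

Compound 4 `CCCc1ccc(C(=O)Nc2cc3nc(C4CCCCC4)[nH]c3cc2N(C)C)cc1` has not yet been measured. It differs from compound 2 by 4-propylphenyl in place of thiophen-2-yl on a carbonyl carbon. Among the measured compounds shown here, the only step that bears on this change, a step that the two limits leave unreadable from compound 1 to compound 2, gives no readable size, so there is no ground to expect movement beyond the scatter in either direction. The expected step of a number no higher from compound 2 to compound 4 (the limit leaves the size open) is therefore close to nil. Compound 4 is accordingly estimated at 100 ug/mL, within the range 40 ug/mL to 250 ug/mL, most likely once more reported as a limit.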

Compound 4, half-maximal inhibitory concentration: > 100 ug/mL
Compound 4: only a limit was reported (the forecaster's own chance of this, stated with the estimate: 80%); the middle value sits exactly at the limit.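

Among these compounds, compound 4 is again reported only as a limit, so no step from compound 1 or compound 2 to compound 4 can be read: the limit of > 100 ug/mL in this assay, at which 4 of the 4 values shown sit. The compounds shown leave open whether any of these groups on the carbonyl carbon changes the result in this assay.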